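Dropping the halogenated anilino group from compound 3

A few compounds are considered here, and "the series" means these few. Any claim that something is new, unique, unknown or untested is made for them only; others in the source may bear on it.

Compound 3 `NS(=O)(=O)c1ccc(NC(=S)Nc2ccc3ncnc(Nc4ccc(Cl)c(C(F)(F)F)c4)c3c2)cc1` gives 4500 nM in a functional assay on A549 cells (Homo sapiens) for antiproliferative activity, read by MTT assay, with a stated time of 72 h (a lower number here means a stronger inhibitor, a higher number a weaker inhibitor), the lowest of the two numbers reported. The nearest neighbour of compound 3 is compound 1 `COc1cc2ncnc(Nc3ccc(F)c(Cl)c3)c2cc1OCCCCC(=O)Nc1ccc(S(N)(=O)=O)cc1`, and in this assay compound 1 gives 15500 nM. Compound 2 `COc1cc2ncnc(Nc3cccc(F)c3)c2cc1OCCCCC(=O)Nc1ccc(S(N)(=O)=O)cc1` reaches only a limit of this assay, > 40000 nM, which is a limit and not a number (the limit of > 40000 nM in this assay, at which 1 of the 3 values shown sits). The step of an at least 2.5-fold higher number from compound 1 to compound 2 (0.41 log units; beyond the scatter) therefore shows that trimming the halogens of the anilino group, 3-fluorophenyl in place of 3-chloro-4-fluorophenyl on a nitrogen on an aromatic ring, costs potency.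

Compound 4 `Cc1cccc(Nc2ncnc3ccc(NC(=S)Nc4ccc(S(N)(=O)=O)cc4)cc23)c1` is the analogue of compound 3 in which (3-methylphenyl in place of 4-chloro-3-(trifluoromethyl)phenyl on a nitrogen on an aromatic ring). Going by the values given here, this removes both the chlorine and the trifluoromethyl from the anilino group, a larger trimming than the one from compound 1 to compound 2, so a weakening beyond the scatter is expected, plausibly of similar or greater size. Compound 4 is therefore estimated at 15000 nM, somewhere between 5000 nM and 45000 nM, which corresponds to an expected step of a 3.3-fold higher number from compound 3 to compound 4 (0.52 log units; beyond the scatter).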

Compound 4, half-maximal inhibitory concentration: > 40000 nM
Compound 4 was reported as a limit (the forecaster's own chance of this, stated with the estimate: 20%); at least 2.6-fold (0.42 log units) between middle value and limit.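

In this assay, replacing 4-chloro-3-(trifluoromethyl)phenyl with 3-methylphenyl on the nitrogen gives an at least 8.8-fold higher number from compound 3 to compound 4 (0.94 log units; beyond the scatter). The loss seen when halogens were trimmed from compound 1 to give compound 2 therefore also appears on a second core, here with no halogen left on the ring at all. The value of compound 4 is a limit and not a number, so the step sets only a minimum for the loss: the limit of > 40000 nM in this assay, at which 2 of the 4 values shown sit.

Which of the chlorine and the trifluoromethyl matters more stays open, and so does any part played by the methyl that enters, as all three change in one step. Going by these compounds, it is also open whether a plain phenyl group, or a phenyl ring carrying chlorine alone or trifluoromethyl alone, would keep the activity of compound 3.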